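Swapping Trifluoromethyl for Nitro on the Aryl Ring

A few compounds are considered here, and "the series" means these few. Any claim that something is new, unique, unknown or untested is made for them only; others in the source may bear on it.

Compounds measured in a functional assay on PC-3 cells (Homo sapiens) for antiproliferative activity, read by MTT assay, with a stated time of 72 h, tested at 5 uM; a lower number here means less inhibition, a higher number more inhibition at the concentration tested (going by the name of the read-out):
compound 1, `CCOC(=O)/C(C#N)=C(/Nc1ccc([N+](=O)[O-])cc1)N[C@H](C)c1ccccc1`: 2.9%
compound 2, `CCOC(=O)/C(C#N)=C(/Nc1ccc(Br)cc1)N[C@@H](C)c1ccccc1`: 24.7%
compound 3, `CCOC(=O)/C(C#N)=C(/Nc1ccc(C(F)(F)F)cc1)N[C@@H](C)c1ccccc1`: 49.1%

Compound 3 stands highest of the three numbers in this assay; compound 2 sits nearest to it and compound 1 furthest, both beyond the scatter. Compound 4, `CCOC(=O)/C(C#N)=C(/Nc1ccc([N+](=O)[O-])cc1)N[C@@H](C)c1ccccc1`, has not been measured. It differs from compound 3 by nitro in place of trifluoromethyl on an aromatic carbon.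

Going by the values given here, no measured step exchanges trifluoromethyl for nitro directly. Among the compounds with values here, the single step that bears on this position is a number 24.4 percentage points higher from compound 2 to compound 3 (beyond the scatter), where trifluoromethyl gave the highest number of the set. Compound 1, which also carries a nitro group, gives only 2.9% in this assay, and this low number points the other way for nitro. The step from compound 3 to compound 4 is therefore expected to be downward and beyond the scatter, a number 34.1 percentage points lower from compound 3 to compound 4 (beyond the scatter). Compound 4 is estimated to give 15% in this assay, within a range of 0% to 38%.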

Compound 4, a percentage reported as inhibition, at one concentration (the size of the read-out at that concentration, not a potency): 0.7%
Estimate against measurement, compound 4: 14.3 percentage points above; the range from low to high includes it.
By their numbers in this assay, from the lowest: compounds 4 and 1 (each within the scatter of the next); then compound 2; then compound 3.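

In this assay, nitro in place of trifluoromethyl on the aromatic carbon para to a large group removes almost all of the inhibition, with a number 48.4 percentage points lower from compound 3 to compound 4 (beyond the scatter). Nitro in place of bromo at the same place also lowers the number, with a number 24 percentage points lower from compound 2 to compound 4 (beyond the scatter), so among the compounds drawn S at the stereocentre, the order from highest to lowest is trifluoromethyl, bromo, nitro. The nitro compounds also show no separation by configuration, with a number 2.2 percentage points lower from compound 1 to compound 4 (within the scatter), and this comparison isolates the stereocentre: the fact that compounds 1 and 4 differ only in the configuration as drawn

As far as these compounds go, whether the drawn configuration matters with trifluoromethyl or bromo at this position stays open. Also open, from the compounds shown here alone, is how an amine or a methoxy group at this position would read in this assay.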